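This account rests on a few compounds, and the source may have more. Where it says the series, first, only, none or still open, it means among the compounds named here.

Compound 1 `CCCS(=O)(=O)Nc1ccc(F)c(C(=O)c2n[nH]c3ncc(-c4ccccc4O)cc23)c1F`: 9%
Compound 2 `CCCS(=O)(=O)Nc1ccc(F)c(C(=O)c2n[nH]c3ncc(-c4ccc(O)cc4)cc23)c1F`: 0.75%
Compound 3 `CCCS(=O)(=O)Nc1ccc(F)c(C(=O)c2n[nH]c3ncc(-c4ccc(F)cc4C)cc23)c1F`: 14%

In an assay for binding affinity to dual specificity mitogen-activated protein kinase kinase 4 (Homo sapiens), read by KINOMEscan, tested at 100 nM (a higher number here means a weaker effect of the compound at the concentration tested, a lower number a stronger effect), compound 1 stands second highest of the three numbers; the steps from it are a number 5 percentage points higher from compound 1 to compound 3 (within the scatter) and a number 8.3 percentage points lower from compound 1 to compound 2 (within the scatter). Compound 4 `CCCS(=O)(=O)Nc1ccc(F)c(C(=O)c2n[nH]c3ncc(-c4ccc(OC)cc4Cl)cc23)c1F` is not yet measured. Relative to compound 1 the change is 2-chloro-4-methoxyphenyl in place of 2-hydroxyphenyl on an aromatic carbon. The closest measured comparison is the step of a number 5 percentage points higher from compound 1 to compound 3 (within the scatter), which also exchanges the 2-hydroxyphenyl for a ring without a hydrogen-bond donor, and the shift of the hydroxyl, a number 8.3 percentage points lower from compound 1 to compound 2 (within the scatter), stayed within the scatter too. No step beyond the scatter is therefore expected in this assay. Compound 4 is estimated at 12%, with a range from 3% to 30%. The expected step is a number 3 percentage points higher from compound 1 to compound 4 (within the scatter).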

Compound 4, a percentage reported as activity, at one concentration (the size of the read-out at that concentration, not a potency): 5.3%
Beside the measured number, compound 4's estimate is 6.7 percentage points above it; measured number inside the range.
By their numbers in this assay, from the lowest: compounds 2, 4, 1 and 3 (each within the scatter of the next, the first and the last beyond it).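

In this assay, the 2-chloro-4-methoxyphenyl of compound 4 fills this position with no hydrogen-bond donor and more heavy atoms than the 2-hydroxyphenyl, yet the read-out stays level (a number 3.7 percentage points lower from compound 1 to compound 4 (within the scatter)). It also sits within the scatter of both other compounds (a number 8.7 percentage points lower from compound 3 to compound 4 (within the scatter); a number 4.6 percentage points higher from compound 2 to compound 4 (within the scatter)), even though those two lie beyond the scatter of each other. No measurement here gives a reason for this.

On these data alone, compound 4 carries the chlorine and the methoxy together, so their separate contributions stay open. Also open, as far as these compounds go, is how a ring bearing an amine or a carboxylic acid would read.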